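Swapping fluoro for methoxy in compound 3

The compounds below may be only part of what the source reports. "The series", "measured", "known", "first", "only" and "open" are said of these compounds alone.

Compound 1 `Nc1ccc(-c2cn(CC(=O)NCc3ccccc3)nn2)cc1`: 1240 uM
Compound 2 `Cc1ccc(-c2cn(CC(=O)NCc3ccccc3)nn2)cc1`: "non-toxic" (no number reported)
Compound 3 `O=C(Cn1cc(-c2cccc(F)c2)nn1)NCc1ccccc1`: "non-toxic" (no number reported)

In an ADME assay on cells (spleen, Mus musculus, strain C57BL/6) for inhibition, read by flow cytometry and propidium iodide staining, with a stated time of 24 h, at 37 degrees C (a lower number here means that less compound is needed, a higher number that more compound is needed for the effect), compound 3 has no single number: compound 3 is reported as "non-toxic" (no number reported), and compound 2 carries the same entry. Only compound 1 has a measured number, 1240 uM.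

Compound 4 `COc1cccc(-c2cn(CC(=O)NCc3ccccc3)nn2)c1` comes from a single swap, methoxy in place of fluoro on an aromatic carbon. Among the measured compounds shown here, no measured pair shows what this swap does. The expectation is therefore no step beyond the usual scatter, in either direction, and compound 4 may also return no number. Should a number appear, the best guide is compound 1 at 1240 uM. For compound 4 the estimated value is 1200 uM, with an expected range of 400 uM to 3000 uM.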

Compound 4, concentration for half-maximal effect: 840 uM
Beside the measured number, compound 4's estimate is 1.4-fold (0.15 log units) above it, within the range that was stated.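

In this assay, compound 4 gives 840 uM, a second real number for this series, while compound 3, with fluoro in that place, carries only the entry "non-toxic", so the swap itself cannot be read as a step. Among the compounds shown here, the one step that can be read is a 1.5-fold lower number from compound 1 to compound 4 (0.17 log units; within the scatter), so 3-methoxyphenyl and 4-aminophenyl cannot be told apart here. No measurement shown explains this result. Going by these compounds, it remains open how a carboxylic acid or an amine would read on this same aromatic carbon, and whether a longer chain than methoxy would also return a number.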